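The compounds below may be only part of what the source reports. "The series", "measured", "known", "first", "only" and "open" are said of these compounds alone.

Measured in a functional assay on BaF3 cells (Mus musculus) for inhibition, read by CCK-8 assay, with a stated time of 72 h; on this read-out lower numbers stand for stronger inhibition of growth and higher numbers for weaker inhibition of growth:
Compound 1 `COc1ccc(CNc2cc(Oc3ccc(NC(=O)Nc4ccc(C)c(C(F)(F)F)c4)cc3)ncn2)cc1`: 1000 nM
Compound 2 `Cc1ccc(NC(=O)Nc2ccc(Oc3cc(N)ncn3)cc2)cc1C(F)(F)F`: > 10000 nM (a limit of the assay, not a number)
Compound 3 `Cc1ccc(NC(=O)Nc2ccc(Oc3cc(N4CCNC[C@@H]4C)ncn3)cc2)cc1C(F)(F)F`: 8120 nM

Of the two actual numbers, compound 3 has the higher one, and the comparison with compound 1 is an 8.1-fold higher number from compound 1 to compound 3 (0.91 log units; beyond the scatter). The next molecule, compound 4 `CCC(=O)Nc1cc(Oc2ccc(NC(=O)Nc3ccc(C)c(C(F)(F)F)c3)cc2)ncn1`, has not yet been measured. It differs from compound 3 at one place on the shared core, with propanoylamino in place of 2-methylpiperazin-1-yl on an aromatic carbon.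

Among the measured compounds shown here, three measured steps concern this same carbon. Replacing the (4-methoxybenzyl)amino group with plain amino gives an at least 10-fold higher number from compound 1 to compound 2 (1.00 log units; beyond the scatter). Replacing it with 2-methylpiperazin-1-yl gives an 8.1-fold higher number from compound 1 to compound 3 (0.91 log units; beyond the scatter). Going from amino to 2-methylpiperazin-1-yl gives an at least 1.2-fold lower number from compound 2 to compound 3 (0.09 log units; that floor lies within the scatter), so these two compounds cannot be ranked.

Compound 4 carries a substituted nitrogen on this carbon, as compound 1 does at 1000 nM, so a modest move towards a lower number than that of compound 3 seems likely, though with wide uncertainty. The expected change is a 4.1-fold lower number from compound 3 to compound 4 (0.61 log units; beyond the scatter). The estimated value for compound 4 is 2000 nM, with an expected range from 300 nM to 10000 nM.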

Compound 4, concentration for 50% growth inhibition: 990 nM
Estimate against measurement, compound 4: 2.0-fold (0.31 log units) above, and the stated range covers the measured number.
By their numbers in this assay, from the lowest: compounds 4 and 1 (each within the scatter of the next); then compound 3. At a limit, above all of these: compound 2.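

In this assay, replacing the 4-methoxybenzyl group on this nitrogen with propanoyl gives a 1.0-fold lower number from compound 1 to compound 4 (0.00 log units; within the scatter), so the two compounds cannot be told apart, and an aromatic ring on this substituent is not needed to reach this level. Adding propanoyl to the plain amino group gives an at least 10-fold lower number from compound 2 to compound 4 (1.00 log units; beyond the scatter), and propanoylamino in place of 2-methylpiperazin-1-yl gives an 8.2-fold lower number from compound 3 to compound 4 (0.91 log units; beyond the scatter), so two quite different groups on this nitrogen now match each other, while compound 3, whose nitrogen also carries substituents but sits in a ring, goes against any rule that substitution alone is enough. The value of compound 2 is a limit of the assay and not a number: the limit of > 10000 nM in this assay, at which 1 of the 4 values shown sits.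

The compounds shown leave open whether the carbonyl of the propanoyl group matters or only the chain, which a propylamino group, with the same chain but no carbonyl, would help to separate. They also leave open how the result changes with chain length, as with a shorter acetyl group or a longer hexanoyl chain on the same nitrogen.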